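Adding a Methoxy Group Next to the Existing One in Compound 1

This account rests on a few compounds, and the source may have more. Where it says the series, first, only, none or still open, it means among the compounds named here.

Compound 1 `COc1ccc(-c2cc(/C=C/C(=O)c3ccc(N)cc3)[nH]n2)cc1` was tested in a functional assay on SK-MEL-5 cells (Homo sapiens) for cytotoxicity, read by sulforhodamine B assay, with a stated time of 48 h, tested at 0.1 uM (a higher number here means a weaker effect of the compound at the concentration tested, a lower number a stronger effect), and gave 90%. Two companions share the same core: compound 2 `COc1cc(-c2cc(/C=C/C(=O)c3ccc(Cl)c(Cl)c3)[nH]n2)cc(OC)c1OC` gives 97% in this assay, and compound 3 `COc1ccc(C(=O)/C=C/c2cc(-c3cc(OC)c(OC)c(OC)c3)n[nH]2)cc1OC` gives 96%. Compound 1 carries the smallest of the three figures, yet neither the gap to compound 3 nor the gap to compound 2 exceeds the scatter, so no order among the three can be read from these numbers.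

For the measured compounds named here, the only measured step, a number 1 percentage points lower from compound 2 to compound 3 (within the scatter), concerns the ring on the carbonyl carbon and leaves the read-out essentially unchanged.

Compound 4 `COc1ccc(-c2cc(/C=C/C(=O)c3ccc(N)cc3)[nH]n2)cc1OC` remains to be measured. It differs from compound 1 by methoxy in place of hydrogen on an aromatic carbon. Going by the values given here, no measured step touches this ring, so the closest guide is the general picture: all three measured compounds sit high in this assay, and the one step on record, a number 1 percentage points lower from compound 2 to compound 3 (within the scatter), stayed within the scatter. On that basis the expected change is a number 1 percentage points higher from compound 1 to compound 4 (within the scatter), nothing beyond the scatter. Compound 4 is therefore estimated at 91% in this assay, within a range from 76% to 100%.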

Compound 4, a percentage reported as activity, at one concentration (the size of the read-out at that concentration, not a potency): 95%
For compound 4 the middle estimate is 4 percentage points below the measured one, within the range that was stated.
By their numbers in this assay, from the lowest: compounds 1, 4, 3 and 2 (each within the scatter of the next).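

In this assay, for the compounds shown here, the step from the ring-bearing single methoxy group to its two-methoxy counterpart is the first to touch this ring, since the earlier step concerned only the ring on the carbonyl carbon. Methoxy in place of hydrogen on this aromatic carbon, ortho to a methoxy group and meta to a large group, gives a number 5 percentage points higher from compound 1 to compound 4 (within the scatter), so this position takes the added group with no change in the read-out that can be told from scatter. The result is a single read-out at one concentration, not a potency, and nothing on hand bears on why the read-out holds steady here.

The compounds shown leave open whether a different group on this same carbon, such as a hydroxyl group, a chlorine atom or the longer ethoxy chain, would move the read-out beyond the scatter. Going by these compounds alone, they also leave open whether the amine on the ring at the carbonyl carbon, shared by compound 1 and compound 4, contributes anything to the read-out, as no step among them replaces it on this core.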